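Double-bond geometry in a small growth-inhibition series

A few compounds are considered here, and "the series" means these few. Any claim that something is new, unique, unknown or untested is made for them only; others in the source may bear on it.

Measured in a functional assay on PC-3 cells (Homo sapiens) for inhibition, read by colorimetric assay and MTT assay; on this read-out higher numbers stand for weaker inhibition of growth and lower numbers for stronger inhibition of growth:
- compound 1 `C=C/C(C)=C/[C@@H](OC(C)=O)[C@H]1C(=C)CC[C@@H]2[C@]1(C)CCC[C@@]2(C)C(=O)O`: 57200 nM
- compound 2 `C=CC(=C)[C@H](C[C@H]1C(=C)CC[C@H]2[C@](C)(CO)CCC[C@]12C)OO`: 50900 nM
- compound 3 `C=CC(=C)CC[C@@H]1[C@@]2(C)CCC[C@](C)(COC(=O)/C=C/c3ccccc3)[C@@H]2CC[C@@]1(C)O`: 10600 nM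

Compound 3 has the lowest number of the three, and the gaps to compound 1 and compound 2 both lie beyond the scatter. Compound 4 `C=CC(=C)CC[C@@H]1[C@@]2(C)CCC[C@](C)(COC(=O)/C=C\c3ccccc3)[C@@H]2CC[C@@]1(C)O` is the next case: the two compounds have the same atoms and bonds and differ only in configuration as drawn: 1 of 6 stereo elements differ; a double bond is drawn E in compound 3 and Z in compound 4. The two compounds have the same atoms and bonds, and a double bond is drawn E in compound 3 and Z in compound 4. Among the compounds with values here, no measured pair shows a change of this kind, so the expectation is loose. In this assay, no step beyond the scatter is expected, with a small rise slightly more likely than a fall. The expected step is a 1.1-fold higher number from compound 3 to compound 4 (0.05 log units; within the scatter). For compound 4, the estimated value is 12000 nM, with an expected range of 6000 nM to 30000 nM.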

Compound 4, concentration for 50% growth inhibition: > 100000 nM
Compound 4: only a limit was reported; the forecaster's own chance of this, stated with the estimate: 5%; at least 8.3-fold (0.92 log units) between middle value and limit.
By their numbers in this assay, from the lowest: compound 3; then compounds 2 and 1 (each within the scatter of the next). At a limit, above all of these: compound 4.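

In this assay, changing only the double bond from E to Z gives an at least 9.4-fold higher number from compound 3 to compound 4 (0.97 log units; beyond the scatter), so drawn geometry at this double bond matters even with atoms and bonds unchanged. Compound 4 reads > 100000 nM, which is a limit and not a number, so the step gives a minimum only: the limit of > 100000 nM in this assay, at which 1 of the 4 values shown sits. The earlier compounds offered no such pair, and this one ties the loss of growth inhibition to geometry alone: the fact that compounds 3 and 4 differ only in the configuration as drawn

Still open, on these data alone, is whether geometry counts equally when an amide replaces the ester. Also open, as far as these compounds go, is whether a saturated chain in place of the double bond would read closer to compound 3 or compound 4.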